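The source may hold more compounds than are shown below. What is called first, only, known or untested is meant among the compounds shown, and "the series" means these compounds.

In an ADME assay (liver) for metabolic stability, with Liver microsome (Canis lupus familiaris) as the target, read by LC-MS, using microsomes, with a stated time of 30 min, tested at 4 uM (on this read-out lower numbers stand for a less stable compound and higher numbers for a more stable compound), compound 1 `Cc1nc(N2CCN(C)CC2)c2nc(-c3ccccc3Cl)n(CCN3CCCC3=O)c2n1` gives 60% and compound 2 `Cc1nc(N2CCN(C)CC2)c2nc(-c3cccc(C(F)(F)F)c3)n(C3CCOCC3)c2n1` gives 44% which is the lower of the two numbers and lies beyond the usual scatter from the other. Compound 3 `Cc1nc(N2CCN(C)CC2)c2nc(-c3ccccc3C3CC3)n(C3CCOCC3)c2n1` differs from compound 2 in one place, on an aromatic carbon, where 2-cyclopropylphenyl stands in place of 3-(trifluoromethyl)phenyl (2-cyclopropylphenyl in place of 3-(trifluoromethyl)phenyl on an aromatic carbon). Within the data shown here, no measured pair shows this change alone, so only a small rise is expected, with a number 4 percentage points higher from compound 2 to compound 3 (within the scatter) as the estimated step, within the scatter. For compound 3 the estimated value is 48% with an expected range from 28% to 68% in this measurement.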

Compound 3, percent of the compound remaining: 69%
Compound 3: the middle estimate sits 21 percentage points below what was measured, and the stated range ends below it.
By their numbers in this assay, from the lowest: compound 2; then compounds 1 and 3 (each within the scatter of the next).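

With the oxan-4-yl group and the rest of the core unchanged, the aryl group on this aromatic carbon matters in this assay, since 2-cyclopropylphenyl in place of 3-(trifluoromethyl)phenyl gives a number 25 percentage points higher from compound 2 to compound 3 (beyond the scatter). The two aryl groups differ both in the substituent and in where it sits on the phenyl ring, and this single step cannot separate the two differences. Nothing available here explains the rise. From the compounds shown here alone, it remains open whether 2-(trifluoromethyl)phenyl would fall nearer to 2-cyclopropylphenyl or to 3-(trifluoromethyl)phenyl. The same question holds for 3-cyclopropylphenyl.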